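This account rests on a few compounds, and the source may have more. Where it says the series, first, only, none or still open, it means among the compounds named here.

Measured so far in an ADME assay on HepG2 cells (Homo sapiens) for cytotoxicity, read by MTT assay, with a stated time of 24 h; a lower number here means that less compound is tolerated, a higher number that more compound is tolerated:
compound 1 `Clc1ccc2c(-n3cc(-c4ccccc4)nn3)ccnc2c1`: 574000 nM
compound 2 `OCCCc1cn(-c2ccnc3cc(Cl)ccc23)nn1`: 151000 nM
compound 3 `Clc1ccc2c(-n3cc(C4CCCCC4)nn3)ccnc2c1`: > 3200 nM (a limit of this assay, not a number)

Compound 2 holds the lowest of the two numbers; its nearest neighbour is compound 1, with a 3.8-fold lower number from compound 1 to compound 2 (0.58 log units; beyond the scatter) separating the two. The value of compound 3 is a limit only (the limit of > 3200 nM in this assay, at which 1 of the 3 values shown sits), so the steps from compound 1 to compound 3 and from compound 2 to compound 3 cannot be sized.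

Compound 4 `CCc1ccc(C(=O)OCCCc2cn(-c3ccnc4cc(Cl)ccc34)nn2)cc1` is not yet measured. It differs from compound 2 in one place: (4-ethylphenyl)carbonyl in place of hydrogen on an oxygen on a saturated carbon. The hydroxyl of the 3-hydroxypropyl chain is thereby capped as an ester.

For the measured compounds named here, no measured step touches that oxygen. Going by the values given here, the only readable step is the swap from compound 1 to compound 2 on the aromatic carbon of the triazole, a modest one, and it does not concern the chain terminus. The unreadable steps to compound 3 add nothing. A step not beyond the scatter is therefore the working expectation for compound 4, with wide uncertainty: a 1.4-fold lower number from compound 2 to compound 4 (0.14 log units; within the scatter). Compound 4 is estimated at 110000 nM, within 30000 nM to 400000 nM, pending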

Compound 4, half-maximal cytotoxic concentration: > 2550000 nM
Compound 4: only a limit was reported; the forecaster's own chance of this, stated with the estimate: 20%; at least 23-fold (1.36 log units) between middle value and limit.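

In this assay, the oxygen on a saturated carbon of the chain proves to be a place where the series responds: (4-ethylphenyl)carbonyl in place of hydrogen gives an at least 16-fold higher number from compound 2 to compound 4 (1.22 log units; beyond the scatter). For the compounds shown here, this is the first readable step at the chain terminus, and its direction is towards more compound being tolerated, so capping the hydroxyl as this ester does not lower the number here. The figure for compound 4 is a limit of this assay and not a number, so the true size of the step remains unknown: the limit of > 2550000 nM in this assay, at which 1 of the 4 values shown sits.

On these data alone, it stays open whether the step belongs to the (4-ethylphenyl)carbonyl group itself or to any replacement of the hydroxyl hydrogen. A methyl ether, an acetyl ester, or an amine or carboxylic acid at the end of the chain would separate these readings.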